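The compounds below may be only part of what the source reports. "The series", "measured", "known", "first", "only" and "open" are said of these compounds alone.

Measured so far in an ADME assay on Vero cells (Chlorocebus sabaeus) for cytotoxicity, read by fluorescence and resazurin assay, with a stated time of 3 days; on this read-out higher numbers stand for lower toxicity in this test and lower numbers for higher toxicity in this test:

Compound 1, `CC1(C)O[C@H]2O[C@H](Cn3cc(CN4C(=O)/C(=N\Nc5ccccc5)c5ccccc54)nn3)[C@H](O)[C@H]2O1`: 82100 nM
Compound 2, `CC1(C)O[C@H]2O[C@H](Cn3cc(CN4C(=O)/C(=N\Nc5ccc(Br)cc5)c5ccccc54)nn3)[C@H](O)[C@H]2O1`: 72900 nM
Compound 3, `O=C1/C(=N\Nc2ccccc2)c2ccccc2N1Cc1cn(O[C@@H]2O[C@H](CO)[C@H](O)[C@H](O)[C@H]2O)nn1`: 83400 nM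

Compound 3 stands among these three values rather than apart from them. Its step from compound 1, a 1.0-fold higher number from compound 1 to compound 3 (0.01 log units; within the scatter), is within the scatter, and the value of compound 2 likewise sits within the scatter of the value of compound 3, so nothing in these numbers separates the three compounds.

The next compound is compound 4, `O=C1/C(=N\Nc2ccc(Br)cc2)c2ccccc2N1Cc1cn(O[C@@H]2O[C@H](CO)[C@H](O)[C@H](O)[C@H]2O)nn1`. It differs from compound 3 in one place: bromo in place of hydrogen on an aromatic carbon. The same change has been measured once before, on another pair sharing the same core: a 1.1-fold lower number from compound 1 to compound 2 (0.05 log units; within the scatter), a step that stays within the scatter. Within the data shown here, that single precedent is the only guide here, and it points to no real movement.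

The expectation for compound 4 is therefore a value close to that of compound 3, with the step of a 1.1-fold lower number from compound 3 to compound 4 (0.04 log units; within the scatter) staying inside the scatter. Compound 4 is estimated at 76000 nM, with a likely range from 40000 nM to 145000 nM.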

Compound 4, half-maximal cytotoxic concentration: 91500 nM
For compound 4 the middle estimate is 1.2-fold (0.08 log units) below the measured one; the measured number falls inside the stated range.
By their numbers in this assay, from the lowest: compounds 2, 1, 3 and 4 (each within the scatter of the next).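

In this assay, the change from phenyl to 4-bromophenyl gives a 1.1-fold higher number from compound 3 to compound 4 (0.04 log units; within the scatter), so a second core also shows no readable effect, and the two steps agree with each other: the same change on two cores in this assay, a 1.1-fold lower number (0.05 log units; within the scatter) from compound 1 to compound 2 and a 1.1-fold higher number (0.04 log units; within the scatter) from compound 3 to compound 4, 1.2-fold (0.09 log units) apart, within the scatter of two such steps. Exchanging the group on the aromatic nitrogen can now be read with bromo present as well, as a 1.3-fold higher number from compound 2 to compound 4 (0.10 log units; within the scatter), and it too leaves the number within the scatter: the same change on two cores in this assay, a 1.0-fold higher number (0.01 log units; within the scatter) from compound 1 to compound 3 and a 1.3-fold higher number (0.10 log units; within the scatter) from compound 2 to compound 4, 1.2-fold (0.09 log units) apart, within the scatter of two such steps. Each change has therefore been seen in two settings, and neither separates any pair of compounds that differ in one place.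

Bromo is the only replacement for hydrogen at this position, so an amine, a carboxylic acid or a methoxy group there remains untested in these compounds. On these data alone, whether bromo on another carbon of that ring would behave the same also stays open.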